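Sulfonamide aryl swap on a benzimidazole enone scaffold

This account rests on a few compounds, and the source may have more. Where it says the series, first, only, none or still open, it means among the compounds named here.

Measured compounds:
Compound 1 `Cc1ccccc1C(=O)Nc1cccc(/C=C/C(=O)c2nc3ccccc3[nH]2)c1`: 5870 nM
Compound 2 `COc1ccc(C(=O)Nc2cccc(/C=C/C(=O)c3nc4ccccc4[nH]3)c2)cc1`: 20100 nM
Compound 3 `O=C(/C=C/c1cccc(NS(=O)(=O)c2ccccc2Cl)c1)c1nc2ccccc2[nH]1`: 4280 nM

Of the compounds shown here, three sharing one core have been tested in a functional assay on MCF7 cells (Homo sapiens) for antiproliferative activity, read by MTT assay, with a stated time of 48 h; a lower number here means a stronger inhibitor, a higher number a weaker inhibitor. Compound 3 gives the lowest number of the three, yet compound 1 sits close to it, as the step of a 1.4-fold lower number from compound 1 to compound 3 (0.14 log units; within the scatter) stays within the scatter. Compound 2 stands apart: the step of a 4.7-fold lower number from compound 2 to compound 3 (0.67 log units; beyond the scatter) is beyond the scatter, as is a 3.4-fold higher number from compound 1 to compound 2 (0.53 log units; beyond the scatter).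

Compound 4 `Cc1ccc(S(=O)(=O)Nc2cccc(/C=C/C(=O)c3nc4ccccc4[nH]3)c2)cc1` has not yet been measured. It differs from compound 3 only in the aryl group on the sulfonyl: 4-methylphenyl in place of 2-chlorophenyl on a sulfonyl sulfur.

Among the measured compounds shown here, no measured step exchanges one aryl group for another on a sulfonyl. The nearest point of comparison is the exchange of aryl groups on the carbonyl, where a 3.4-fold higher number from compound 1 to compound 2 (0.53 log units; beyond the scatter) shows a modest loss when a 2-substituted ring gives way to a 4-substituted one. The steps of a 1.4-fold lower number from compound 1 to compound 3 (0.14 log units; within the scatter) and a 4.7-fold lower number from compound 2 to compound 3 (0.67 log units; beyond the scatter) concern the linker, not the aryl, and bear only indirectly on the question. On that basis compound 4 is expected to give a somewhat higher number than compound 3, roughly a 1.8-fold higher number from compound 3 to compound 4 (0.24 log units; within the scatter), though a step within the scatter cannot be excluded. The estimate for compound 4 in this assay is 7500 nM, with a range from 2500 nM to 22000 nM.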

Compound 4, half-maximal inhibitory concentration: 3220 nM
Compound 4: middle estimate off by 2.3-fold (0.37 log units), on the high side; low and high end bracket the measured number.
By their numbers in this assay, from the lowest: compounds 4, 3 and 1 (each within the scatter of the next); then compound 2.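

In this assay, the exchange of aryl groups on a sulfonyl sulfur, 4-methylphenyl in place of 2-chlorophenyl, gives (a 1.3-fold lower number from compound 3 to compound 4 (0.12 log units; within the scatter)), so this change at this position leaves the result within the scatter, unlike the exchange of aryl groups on the carbonyl (a 3.4-fold higher number from compound 1 to compound 2 (0.53 log units; beyond the scatter)). The loss seen on the carbonyl with 4-methoxyphenyl is therefore not repeated on the sulfonyl with 4-methylphenyl, although these are different groups on different linkers. The new sulfonamide stays level with the carbonyl compound bearing 2-methylphenyl (a 1.8-fold lower number from compound 1 to compound 4 (0.26 log units; within the scatter)) and parts from the one bearing 4-methoxyphenyl (a 6.2-fold lower number from compound 2 to compound 4 (0.80 log units; beyond the scatter)), leaving that carbonyl compound alone at the weak end of the set, and no measurement shown here offers an explanation for any of these steps.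

Only two aryl groups on the sulfonyl are shown, so it remains open whether 4-methoxyphenyl would behave there as it does on the carbonyl. As far as these compounds go, it is equally open whether this tolerance would extend to an aryl ring carrying an amine or a carboxylic acid, or to a longer chain in place of the aryl group on the sulfonyl sulfur.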